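A Fluorine Added to the Unsaturated Ketone Arm

The compounds below may be only part of what the source reports. "The series", "measured", "known", "first", "only" and "open" are said of these compounds alone.

Compound 1 `COc1ccc(-c2cc3ccccc3nc2C=O)cc1` carries a carbonyl directly on the shared core. In a functional assay on NCI-H1299 cells (Homo sapiens) for antiproliferative activity, read by XTT assay, with a stated time of 72 h (a higher number here means a weaker inhibitor, a lower number a stronger inhibitor), compound 1 reaches only a limit, > 10000 nM, as reflected in the limit of > 10000 nM in this assay, at which 1 of the 2 values shown sits. Among the measured compounds shown here, compound 2 `COc1ccc(-c2cc3ccccc3nc2/C=C/C(=O)c2ccccc2)cc1` extends that carbonyl into an unsaturated ketone ending in a phenyl ring; in this assay compound 2 gives 1410 nM, the only number among the values shown. Compound 3 `COc1ccc(-c2cc3ccccc3nc2/C=C/C(=O)c2ccc(F)cc2)cc1` differs from compound 2 by fluoro in place of hydrogen on an aromatic carbon. For the measured compounds named here, no measured pair shows this change, so the step is expected to stay within the scatter: a 1.2-fold lower number from compound 2 to compound 3 (0.07 log units; within the scatter). Compound 3 is therefore estimated at 1200 nM, between 500 nM and 3000 nM.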

Compound 3, half-maximal inhibitory concentration: 820 nM
Compound 3: the middle estimate sits 1.5-fold (0.17 log units) above what was measured; measured number inside the range.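

In this assay the change from phenyl to 4-fluorophenyl gives a 1.7-fold lower number from compound 2 to compound 3 (0.24 log units; within the scatter) and so cannot be told apart from repeat measurement. This position on the unsaturated ketone arm therefore accepts a fluoro group in place of hydrogen with no readable change in antiproliferative activity. No measurement shown here speaks to why this step is so small.

As far as these compounds go, whether an amine or a carboxylic acid at this same position would move the number beyond the scatter stays open. So does the effect of a longer chain between the carbonyl and the shared core.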